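The source may report more compounds than this note shows. Statements on the series, on what has been measured and on what is new or still open speak of the compounds shown alone.

Working notes on the series.

Compound 1 `CSc1nn(-c2ccccc2)c2nc(Nc3ccccc3)n(-c3ccccc3)c(=O)c12` is the reference. In a functional assay on the whole organism (strain Wistar albino) for inhibition, with Rattus norvegicus as the target, read by paw edema, with a stated time of 2 h, at a dose of 25 mg/kg by the oral route (on this read-out lower numbers stand for less inhibition and higher numbers for more inhibition at the one dose given (going by the name of the read-out)), compound 1 gives 36.6%. Compound 2 `CSc1nn(-c2ccc([N+](=O)[O-])cc2)c2nc(Nc3ccccc3)n(-c3ccccc3)c(=O)c12` differs from compound 1 by nitro in place of hydrogen on an aromatic carbon, and in this assay compound 2 gives 37.7%. The step of a number 1.1 percentage points higher from compound 1 to compound 2 (within the scatter) is too small to carry any reading of direction.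

Compound 3 `O=c1c2c(Nc3ccc(Cl)cc3)nn(-c3ccccc3)c2nc(Nc2ccccc2)n1-c1ccccc1` carries a different core: relative to compound 1 the difference is (4-chlorophenyl)amino in place of methylsulfanyl on an aromatic carbon. In this assay compound 3 gives 44%. The step of a number 7.4 percentage points higher from compound 1 to compound 3 (within the scatter) likewise lies inside the scatter, and the gap between compound 3 and compound 2 is inside the scatter as well, so the three measured compounds cannot be ordered on this read-out.

Compound 4 `O=c1c2c(Nc3ccc(Cl)cc3)nn(-c3ccc([N+](=O)[O-])cc3)c2nc(Nc2ccccc2)n1-c1ccccc1` is not yet measured. It differs from compound 3 by nitro in place of hydrogen on an aromatic carbon. The place of this change is described in the same words as for the pair compound 1 to compound 2, so it is the same change made on the core of compound 3 rather than on the core of compound 1. For the measured compounds named here, the only precedent for it is a number 1.1 percentage points higher from compound 1 to compound 2 (within the scatter), a step that did not move the read-out beyond the scatter. On that basis the step from compound 3 to compound 4 is expected to be of comparable size, a number 1 percentage points higher from compound 3 to compound 4 (within the scatter), because the earlier step of a number 1.1 percentage points higher from compound 1 to compound 2 (within the scatter) was essentially flat. For compound 4 in this assay a value of 45% is therefore estimated, with a range from 35% to 55%, resting on the value of compound 3, 44%, and on the flat step in the first pair. Whether the change on the core of compound 3 behaves as it did on the core of compound 1 can only be settled by the measurement.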

Compound 4, a percentage reported as inhibition, in the whole organism at one dose (the size of the read-out at that dose, not a potency): 39%
Compound 4: the middle estimate sits 6 percentage points above what was measured; low and high end bracket the measured number.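

In this assay, nitro in place of hydrogen on an aromatic carbon gives a number 5 percentage points lower from compound 3 to compound 4 (within the scatter), and (4-chlorophenyl)amino in place of methylsulfanyl gives a number 1.3 percentage points higher from compound 2 to compound 4 (within the scatter). For the nitro change, the step on the core of compound 3 cannot be told apart from the step on the core of compound 1: the same change on two cores in this assay, a number 1.1 percentage points higher (within the scatter) from compound 1 to compound 2 and a number 5 percentage points lower (within the scatter) from compound 3 to compound 4, 6.1 percentage points apart, within the scatter of two such steps. For the compounds shown here, the same holds for the (4-chlorophenyl)amino change, so neither change is seen to depend on the core, but this does not show that either change carries over unaltered, as all of these steps and the gaps between them lie inside the scatter and each change rests on only two pairs: the same change on two cores in this assay, a number 7.4 percentage points higher (within the scatter) from compound 1 to compound 3 and a number 1.3 percentage points higher (within the scatter) from compound 2 to compound 4, 6.1 percentage points apart, within the scatter of two such steps.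

The compounds shown leave open whether any change at these two places can move the read-out beyond the scatter at the one dose and time given. A carboxylic acid or an amine on the phenyl ring in place of nitro, or a longer chain in place of methylsulfanyl, would test this, and a further pair on a third core would show whether these steps hold beyond the two cores shown here.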